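This account rests on a few compounds, and the source may have more. Where it says the series, first, only, none or still open, it means among the compounds named here.

Measured so far in a functional assay on SK-OV-3 cells (Homo sapiens) for cytotoxicity, read by spectrophotometry, with a stated time of 72 h; on this read-out higher numbers stand for weaker inhibition and lower numbers for stronger inhibition:
- compound 1 `COc1ccc(-c2cccc(=O)n2-c2cc(OC)c(OC)c(OC)c2)cc1`: < 10 nM (a limit of the assay, not a number)
- compound 2 `COc1cc(-n2c(-c3cccc(O)c3)cccc2=O)cc(OC)c1OC`: 1460 nM

Among the compounds with values here, compound 2 gives the only true number in this small set, 1460 nM. Compound 1 gives only a limit, < 10 nM. The next molecule, compound 3 `COc1cc(-n2c(-c3cccc4cc[nH]c34)cccc2=O)cc(OC)c1OC`, keeps the shared core and changes the same place again: 1H-indol-7-yl in place of 3-hydroxyphenyl on an aromatic carbon. Here 1H-indol-7-yl takes the place of 3-hydroxyphenyl.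

Within the data shown here, one measured step bears on this change: an at least 140-fold higher number from compound 1 to compound 2 (2.16 log units; beyond the scatter). That large step shows that the group at this place can move the result in this assay a long way. It offers only indirect guidance, since neither compound carries the new group. A clear step therefore seems more likely than none, with a cautious lean towards stronger inhibition, as compound 2 lies so far from the limit of compound 1. The expected change is a 4.9-fold lower number from compound 2 to compound 3 (0.69 log units; beyond the scatter), and this estimate is loose. For compound 3 the estimated value is 300 nM, with an expected range from 25 nM to 3000 nM.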

Compound 3, half-maximal inhibitory concentration: 138 nM
The estimate for compound 3 lay 2.2-fold (0.34 log units) above the measured number, and the stated range covers the measured number.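

In this assay, within the data shown here, the earlier compounds showed only that this place next to the ring nitrogen can cost a great deal of activity; compound 3 shows that much of that loss can be won back. Putting 1H-indol-7-yl in place of 3-hydroxyphenyl gives an 11-fold lower number from compound 2 to compound 3 (1.02 log units; beyond the scatter), so a group with a second ring is accepted here, and it does better than the single ring of 3-hydroxyphenyl even though both groups count one hydrogen-bond donor. The recovery is only partial, with an at least 13-fold higher number from compound 1 to compound 3 (1.13 log units; beyond the scatter), and the true size of that gap stays unknown, as compound 1 gives only a limit of the assay and not a number: the limit of < 10 nM in this assay, at which 1 of the 3 values shown sits.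

The compounds shown do not separate the part played by the nitrogen of 1H-indol-7-yl from that of its second ring, a question that a naphthyl group, with carbon rings only, would address. They also leave open how a phenyl ring carrying an amine would compare with 4-methoxyphenyl and 3-hydroxyphenyl at this place.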